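The source may hold more compounds than are shown below. What is called first, only, known or untested is meant among the compounds shown, and "the series" means these compounds.

Measured so far in a functional assay on HeLa cells (Homo sapiens) for inhibition, read by cell counting, with a stated time of 96 h; on this read-out lower numbers stand for stronger inhibition and higher numbers for weaker inhibition 
- compound 1 (`CCN(CC)CN1C(=O)/C(=N/NC(=S)Nc2ccccc2)c2cc(Cl)ccc21`) gives 34000 nM 
- compound 2 (`CCN(CC)CN1C(=O)/C(=N/NC(=S)Nc2ccc(Cl)cc2)c2ccccc21`) gives 7600 nM 

Compound 1 stands at the higher of the two numbers, and compound 2 lies below it by more than the usual scatter. Of these two, compound 1 is therefore the weaker inhibitor in this assay and compound 2 the stronger.

Compound 3 (`CCN(CC)CN1C(=O)/C(=N/NC(N)=S)c2cc(Cl)ccc21`) has not yet been measured. It differs from compound 1 by hydrogen in place of phenyl on an amide-type nitrogen, which reads as anilino to amino.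

Within the data shown here, no two measured compounds differ in one place only, so the data give no direct size for this change. A small step towards a higher number in this assay is expected, and a result within the scatter would fit as well. The expected change is a 1.3-fold higher number from compound 1 to compound 3 (0.12 log units; within the scatter) and it carries a wide margin. Among the measured compounds shown here, the only close reference is compound 1 at 34000 nM and the range is kept broad for that reason. For compound 3 the estimated value is 45000 nM with an expected range from 15000 nM to 130000 nM and a report as a limit of the assay remains possible.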

Compound 3, half-maximal inhibitory concentration: 44000 nM
For compound 3 the middle estimate is 1.0-fold (0.01 log units) above the measured one; the measured number falls inside the stated range.
By their numbers in this assay, from the lowest: compound 2; then compounds 1 and 3 (each within the scatter of the next).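

In this assay, hydrogen in place of phenyl on an amide-type nitrogen, whose other neighbour is the thiocarbonyl carbon, gives a 1.3-fold higher number from compound 1 to compound 3 (0.11 log units; within the scatter). Among these compounds, this is the first direct reading at this position, and on this read-out the anilino and amino forms cannot be told apart, so the phenyl group is not needed for the level of inhibition that compound 1 shows on the shared core. No independent measurement at hand bears on why the two forms read alike.

The compounds shown leave open whether other groups on this nitrogen, such as methyl, a longer chain like n-butyl or a cyclohexyl ring, would also read alike, or whether only phenyl and hydrogen do. The gap between compound 1 and compound 2 also stays unassigned, since they differ in more than one place, so neither the place of the chlorine on the core nor the chlorine on the phenyl ring can be credited with it, and the same nitrogen change on the core of compound 2 remains an open question.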